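A few compounds are considered here, and "the series" means these few. Any claim that something is new, unique, unknown or untested is made for them only; others in the source may bear on it.

Compound 2 `COc1cccc([C@H]2O[C@H](CC(=O)N[C@@H](C)C(=O)O)C(=O)N(CC(C)(C)CO)c3ccc(Cl)cc32)c1OC`, compound 1 `COc1cccc([C@H]2O[C@H](CC(=O)N(C)CC(=O)O)C(=O)N(CC(C)(C)CO)c3ccc(Cl)cc32)c1OC` and compound 3 `COc1cccc([C@H]2O[C@H](CC(=O)N3CCC(CC(=O)O)CC3)C(=O)N(CC(C)(C)CO)c3ccc(Cl)cc32)c1OC` share one core and differ only in the acid-bearing amide. In a functional assay on the whole organism for inhibition, with Rattus norvegicus as the target, at a dose of 10 mg/kg by the oral route (a lower number here means less inhibition, a higher number more inhibition at the dose given (going by the name of the read-out)), compound 1 gives -1%, while compound 2 gives 14%, so that a number 15 percentage points higher from compound 1 to compound 2 (beyond the scatter). Compound 3 gives 77%; 64% (2 entries), appearing twice in this assay, as the several entries of compound 3 in this assay, 77%; 64% (2 entries), and those two entries are not reduced to a single number. Among the single numbers shown, compound 2 stands highest, with compound 1 nearest and lower by a margin beyond the scatter. Compound 4 `COc1cccc([C@H]2O[C@H](CC(=O)N[C@H](C)C(=O)O)C(=O)N(CC(C)(C)CO)c3ccc(Cl)cc32)c1OC` differs from compound 2 as follows: the two compounds have the same atoms and bonds and differ only in configuration as drawn: 1 of 3 stereo elements differ; a stereocentre at a saturated chain carbon is drawn S in compound 2 and R in compound 4. Among the compounds with values here, no measured step bears directly on a change of configuration alone; the one step available, from compound 1 to compound 2, concerns a different amide and was modest in size. A change of this kind is therefore expected to give a step no larger than that one, more likely downward than upward, and a number 8 percentage points lower from compound 2 to compound 4 (within the scatter) is the step expected here. On that basis compound 4 is expected to give 6%, with a range from -10% to 28%.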

Compound 4, a percentage reported as inhibition, in the whole organism at one dose (the size of the read-out at that dose, not a potency): 31%
Compound 4: the middle estimate sits 25 percentage points below what was measured, outside the stated range (above it).
By their numbers in this assay, from the lowest: compound 1; then compound 2; then compound 4.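

The change from S to R at the saturated chain carbon gives a number 17 percentage points higher from compound 2 to compound 4 (beyond the scatter) in this assay, so this stereocentre has a measurable bearing on the read-out at this dose. That step can be assigned to configuration alone because of one fact: the fact that compounds 2 and 4 differ only in the configuration as drawn. With the R centre, (1-carboxyethyl)amino in place of (carboxymethyl)(methyl)amino gives a number 32 percentage points higher from compound 1 to compound 4 (beyond the scatter), so what that exchange is worth depends on the configuration drawn.

From the compounds shown here alone, whether R stays ahead of S with an ethyl or a benzyl group at that stereocentre remains open. Both entries of compound 3, 77%; 64% (2 entries), stand above the value of compound 4, and the compounds shown do not tell which part of its different amide carries that gap.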